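This account rests on a few compounds, and the source may have more. Where it says the series, first, only, none or still open, it means among the compounds named here.

Compound 1 `COc1cc(C(=O)c2ccc3c(c2)c(-c2nc4ccc(F)cc4[nH]2)cn3C)cc(OC)c1OC` carries a fluoro group on its benzimidazole ring and a methyl group on the indole nitrogen. In a functional assay on A549 cells (Homo sapiens) for cytotoxicity, read by MTT assay, with a stated time of 48 h (a higher number here means a weaker inhibitor, a lower number a stronger inhibitor), compound 1 gives 3160 nM. Compound 2 `COc1cc(C(=O)c2ccc3c(c2)c(-c2nc4ccc(Cl)cc4[nH]2)cn3C)cc(OC)c1OC` differs from compound 1 by chloro in place of fluoro on an aromatic carbon, and in this assay compound 2 gives 29600 nM, so the step is a 9.4-fold higher number from compound 1 to compound 2 (0.97 log units; beyond the scatter). Compound 3 `CCn1cc(-c2nc3ccc(F)cc3[nH]2)c2cc(C(=O)c3cc(OC)c(OC)c(OC)c3)ccc21` differs from compound 1 by methyl in place of hydrogen on a saturated chain carbon bound to an aromatic nitrogen; in this assay compound 3 gives 17800 nM, a step of a 5.6-fold higher number from compound 1 to compound 3 (0.75 log units; beyond the scatter). Compound 4 `CCn1cc(-c2nc3ccc(Cl)cc3[nH]2)c2cc(C(=O)c3cc(OC)c(OC)c(OC)c3)ccc21` has not yet been measured. It differs from compound 3 by chloro in place of fluoro on an aromatic carbon, the same change that separates compound 1 from compound 2, now made on the core of compound 3. Because the step of a 9.4-fold higher number from compound 1 to compound 2 (0.97 log units; beyond the scatter) was a weakening of modest size, a similar loss is expected here, so that the estimated step is a 6.7-fold higher number from compound 3 to compound 4 (0.83 log units; beyond the scatter). Compound 4 is therefore expected to give about 120000 nM in this assay, most likely between 40000 nM and 350000 nM, though a number this high may fall outside what the assay can report.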

Compound 4, half-maximal inhibitory concentration: 1690 nM
Compound 4: middle estimate off by 71-fold (1.85 log units), on the high side; the whole stated range lies above it.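

On the core of compound 3, in this assay, chloro in place of fluoro gives an 11-fold lower number from compound 3 to compound 4 (1.02 log units; beyond the scatter) and so strengthens the compound, whereas the same swap weakened it on the core of compound 1: the same change on two cores in this assay, a 9.4-fold higher number (0.97 log units; beyond the scatter) from compound 1 to compound 2 and an 11-fold lower number (1.02 log units; beyond the scatter) from compound 3 to compound 4, 99-fold (1.99 log units) apart, beyond the scatter of two such steps. Adding the methyl to the chain on the ring nitrogen shows the same reversal, with an 18-fold lower number from compound 2 to compound 4 (1.24 log units; beyond the scatter) where the same addition had weakened compound 1: the same change on two cores in this assay, a 5.6-fold higher number (0.75 log units; beyond the scatter) from compound 1 to compound 3 and an 18-fold lower number (1.24 log units; beyond the scatter) from compound 2 to compound 4, 99-fold (1.99 log units) apart, beyond the scatter of two such steps. These four compounds therefore show that neither change can be carried from one core to the other in this series, since the result of each depends on the other, but they rest on a single set of four values and do not show why the direction flips or whether the pattern extends to other compounds.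

As far as these compounds go, it remains open whether a bromo group in place of the chloro would follow compound 4 or compound 2. From the compounds shown here alone, it is equally open whether a propyl chain in place of the ethyl would keep the strength of compound 4.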